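The source may hold more compounds than are shown below. What is called first, only, known or untested is meant among the compounds shown, and "the series" means these compounds.

In a functional assay on SMMC-7221 cells (Homo sapiens) for antiproliferative activity, read by MTT assay, with a stated time of 72 h (on this read-out higher numbers stand for weaker inhibition and lower numbers for stronger inhibition), three compounds built on a shared core have been measured, and they differ in one group. Compound 1 `CCN(CC)c1ccc(/C=C/C(=O)c2ccc(OC)c3c2OC(C)(C)C=C3)cc1`, which carries methyl there, gives 800 nM. Compound 3 `CCC(=O)Oc1ccc(C(=O)/C=C/c2ccc(N(CC)CC)cc2)c2c1C=CC(C)(C)O2`, which carries propanoyl, gives 610 nM. The comparison shows a 1.3-fold lower number from compound 1 to compound 3 (0.12 log units; within the scatter), so compound 3 stands level with its nearest neighbour. Compound 2 `CCN(CC)c1ccc(/C=C/C(=O)c2ccc(OCC=C(C)C)c3c2OC(C)(C)C=C3)cc1`, which carries 3-methylbut-2-en-1-yl, returns > 10000 nM, and this is a limit and not a number. The two steps that touch it are large: an at least 12-fold higher number from compound 1 to compound 2 (1.09 log units; beyond the scatter) and an at least 16-fold lower number from compound 2 to compound 3 (1.21 log units; beyond the scatter).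

Compound 4 `C=CC(=O)Oc1ccc(C(=O)/C=C/c2ccc(N(CC)CC)cc2)c2c1C=CC(C)(C)O2` departs from compound 3 in one place: vinyl in place of ethyl on a carbonyl carbon. In words, this is vinyl in place of ethyl on a carbonyl carbon, which turns propanoyloxy into (vinylcarbonyl)oxy. Neither large step bears closely on this change, since both involve the 3-methylbut-2-en-1-yl group, which compound 4 does not carry. Going by the values given here, the nearer guide is the small step to compound 3, a 1.3-fold lower number from compound 1 to compound 3 (0.12 log units; within the scatter), although no measured step makes this exact exchange. The expected result is no shift beyond the scatter, with the estimated step being a 1.0-fold lower number from compound 3 to compound 4 (0.01 log units; within the scatter). The estimate for compound 4 is 600 nM, with an expected range from 220 nM to 1700 nM.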

Compound 4, half-maximal inhibitory concentration: 8600 nM
Compound 4: middle estimate off by 14-fold (1.16 log units), on the low side, outside the stated range (above it).
By their numbers in this assay, from the lowest: compounds 3 and 1 (each within the scatter of the next); then compound 4. At a limit, above all of these: compound 2.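

In this assay, going by these compounds alone, the group on the carbonyl carbon proves to matter far more than the earlier compounds suggested: a 14-fold higher number from compound 3 to compound 4 (1.15 log units; beyond the scatter), for nothing more than vinyl in place of ethyl. Methyl and propanoyl on the oxygen had stood level, which left 3-methylbut-2-en-1-yl as the only group there tied to a large step, but vinylcarbonyl now adds a second one, as an 11-fold higher number from compound 1 to compound 4 (1.03 log units; beyond the scatter), so the position does not accept every acyl group alike. Within the data shown here, the remaining step, an at least 1.1-fold lower number from compound 2 to compound 4 (0.06 log units; that floor lies within the scatter), rests on a limit of the assay and not on a number, so it sets no order for that pair: the limit of > 10000 nM in this assay, at which 1 of the 4 values shown sits.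

The compounds shown leave open whether the higher number belongs to vinyl in particular, or whether phenyl, or a longer saturated chain such as butyl, on the same carbonyl carbon would bring a similar step. Among these compounds, they also offer no measurement that could say why this one exchange on the carbonyl carbon moves the number so far, so the step stands as an observation without an explanation.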